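Benzyloxy in place of benzyl on the amine nitrogen

The compounds below may be only part of what the source reports. "The series", "measured", "known", "first", "only" and "open" are said of these compounds alone.

Measured in an ADME assay on THP-1 cells (Homo sapiens) for cytotoxicity, read by trypan blue exclusion, with a stated time of 48 h; a higher number here means a weaker inhibitor of growth, a lower number a stronger inhibitor of growth:
- compound 1 `Cc1cc(/C=N\OCc2ccccc2)c(C)n1-c1ccc(Cl)cc1`: 500 ug/mL
- compound 2 `Cc1cc(CNCc2ccccc2)c(C)n1-c1ccc(F)cc1`: 28 ug/mL
- compound 3 `Cc1cc(CNCc2ccccc2)c(C)n1-c1ccc(Cl)cc1`: 7.2 ug/mL

Compound 2 holds the middle place of these three numbers. The next compound is compound 4 `Cc1cc(CNOCc2ccccc2)c(C)n1-c1ccc(F)cc1`, which has benzyloxy in place of benzyl on an amine nitrogen.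

Among the compounds with values here, the only measured single-site step is a 3.9-fold lower number from compound 2 to compound 3 (0.59 log units; beyond the scatter). It is a modest step, with chloro in place of fluoro on an aromatic carbon, so it bears on the change only as a guide to size. Compound 1, which carries benzyloxy, gives 500 ug/mL, whereas compound 3, which carries benzyl, gives 7.2 ug/mL. These two differ in more than that group, so the comparison is weak evidence.

On this evidence, a modest move to a higher number is expected in this assay, similar in size to the halogen step. The expected change is a 3.2-fold higher number from compound 2 to compound 4 (0.51 log units; beyond the scatter). For compound 4 the estimate is 90 ug/mL, with an expected range of 25 ug/mL to 350 ug/mL.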

Compound 4, concentration for 50% growth inhibition: 292 ug/mL
Compound 4: the middle estimate sits 3.2-fold (0.51 log units) below what was measured, and the stated range covers the measured number.
By their numbers in this assay, from the lowest: compound 3; then compound 2; then compounds 4 and 1 (each within the scatter of the next).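

In this assay, within the data shown here, the first single-site reading at this position, on an amine nitrogen whose other neighbours are saturated chain carbon, is a 10-fold higher number from compound 2 to compound 4 (1.02 log units; beyond the scatter) for the change to benzyloxy. Among these compounds, the only earlier single-site reading, a 3.9-fold lower number from compound 2 to compound 3 (0.59 log units; beyond the scatter), concerned the halogen and ran in the opposite direction, so this change at the amine nitrogen is a large step in its own right, not a minor variation on benzyl. Nothing measured here explains the size of this step.

The compounds shown leave open whether the step depends on the added oxygen itself or on the longer link, a question that a phenethyl group on the amine nitrogen would address. Also open, from the compounds shown here alone, is whether the same change gives a step of similar size when chloro replaces fluoro, starting from compound 3.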